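The source may hold more compounds than are shown below. What is called first, only, known or untested is meant among the compounds shown, and "the series" means these compounds.

Measured so far:
- compound 1, `CC(C)N(C)/N=N/c1ccc(C(N)=O)cc1`: in a functional assay on L1210 cells (Mus musculus) for antiproliferative activity (on this read-out higher numbers stand for higher potency (the scale is a negative logarithm) and lower numbers for lower potency), compound 1 gives 3.17
- compound 2, `C=CCN(C)/N=N/c1ccccc1C(N)=O`: in this assay compound 2 gives 3.43

Within the data shown here, only these two compounds have been measured, and no pair among them differs in a single place, so no step can be read off. Compound 2 has the higher of the two numbers, but compound 1 lies within the usual scatter of it, so the two cannot be told apart with confidence; all that can be said is that both sit in the same modest range of this assay.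

The next compound, compound 3, `CCCCN(C)/N=N/c1ccccc1C(N)=O`, differs from compound 2 in one place: propyl in place of vinyl on a saturated chain carbon bound to an amine nitrogen. The shared core and the attached amide are untouched; only the small chain on the amine nitrogen changes.

Among the measured compounds shown here, with no comparable step to lean on, the expectation for compound 3 rests on compound 2 alone, whose value 3.43 is the starting point; the step of a number 0.03 log units lower from compound 2 to compound 3 (within the scatter) is expected to be small, with no clear direction beyond the scatter. Compound 3 is therefore estimated at 3.4 in this assay, within a range from 2.9 to 3.9.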

Compound 3, logarithm of the reciprocal of the active concentration, log(1/C): 3.1
Compound 3: middle estimate off by 0.30 log units, on the high side; low and high end bracket the measured number.
By their numbers in this assay, from the lowest: compounds 3, 1 and 2 (each within the scatter of the next, the first and the last beyond it).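

In this assay, among these compounds, the small chain on the amine nitrogen can now be judged from a single change for the first time: swapping allyl for butyl, which is propyl in place of vinyl on the saturated chain carbon, gives a number 0.33 log units lower from compound 2 to compound 3 (beyond the scatter) and so shows that this place is not indifferent to what sits on it. The change is not a simple one, since vinyl, with 2 heavy atoms and a double bond, leaves, while propyl, with 3 heavy atoms and no double bond, enters, so chain size and the double bond change together, with no hydrogen-bond donors, acceptors or charge involved on either side. Nothing measured here accounts for the lower number.

The compounds shown leave open whether the double bond or the chain length matters more, a question that a plain propyl chain on the amine nitrogen, the saturated counterpart of allyl, would address directly. They also leave open how a longer chain such as hexyl, or a chain ending in a hydroxyl group or an amine, would fare at this place.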